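The source may report more compounds than this note shows. Statements on the series, on what has been measured and on what is new or still open speak of the compounds shown alone.

Measured compounds in a functional assay (trachea) for antagonist activity, with Cavia porcellus as the target; on this read-out higher numbers stand for higher potency (the scale is a negative logarithm) and lower numbers for lower potency:
- compound 1 `COc1cc(C(=O)NS(=O)(=O)c2cc(C)ccc2C)ccc1Cn1ccc2ccc(NC(=O)CC3CCCC3)cc21` gives 8.4
- compound 2 `CCCCC(CC)C(=O)Nc1ccc2ccn(Cc3ccc(C(=O)C(C#N)S(=O)(=O)c4ccccc4)cc3OC)c2c1` gives 8.1
- compound 3 `CCCCC(CC)C(=O)Nc1ccc2ccn(Cc3ccc(C(=O)C(C(=O)OC)S(=O)(=O)c4ccccc4)cc3OC)c2c1` gives 8.5

Compound 1 sits in the middle of these three numbers, with compound 3 and compound 2 on either side, and both gaps lie within the usual scatter, so the three are not separable on this read-out. For the measured compounds named here, the only single-site step measured is a number 0.40 log units higher from compound 2 to compound 3 (beyond the scatter), which alters the chain carbon bound to the carbonyl and the sulfonyl, not the aryl on the sulfonyl sulfur.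

Compound 4 `COc1cc(C(=O)NS(=O)(=O)c2ccccc2N)ccc1Cn1ccc2ccc(NC(=O)CC3CCCC3)cc21` differs from compound 1 by 2-aminophenyl in place of 2,5-dimethylphenyl on a sulfonyl sulfur. Going by the values given here, no measured step touches this position, so nothing in the data speaks for a shift in either direction. Compound 4 is therefore expected to stay near compound 1, an estimated step of a number 0.10 log units lower from compound 1 to compound 4 (within the scatter), giving an estimate of 8.3 with a range from 7.7 to 8.9.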

Compound 4, negative logarithm of the antagonist equilibrium constant: 9.9
Beside the measured number, compound 4's estimate is 1.60 log units below it; measured number outside the range, above it.
By their numbers in this assay, from the lowest: compounds 2, 1 and 3 (each within the scatter of the next, the first and the last beyond it); then compound 4.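

For the compounds shown here, on the sulfonyl sulfur, the aryl group is a sensitive site in this assay: 2-aminophenyl in place of 2,5-dimethylphenyl gives a number 1.50 log units higher from compound 1 to compound 4 (beyond the scatter) and is the first measured change at this position. The exchange removes both methyl groups and introduces the amino group in a single step, so the data cannot assign the gain to either part of the change. No available evidence bears on the origin of this gain.

Still open, as far as these compounds go, is whether the amino group alone accounts for the gain. Unsubstituted phenyl, 2-methylphenyl and 2-hydroxyphenyl on the sulfonyl sulfur would help separate these contributions.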